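Working notes: triazole substituent swap in a cell growth series

A few compounds are considered here, and "the series" means these few. Any claim that something is new, unique, unknown or untested is made for them only; others in the source may bear on it.

Measured compounds
- compound 1 `CCCCCCCCn1cc(COC2(C(F)(F)F)Oc3ccccc3C=C2C(=O)OCC)nn1`: > 150000 nM
- compound 2 `O=C(O)C1=Cc2ccccc2OC1(OCc1cc(-c2ccc3ccccc3c2)no1)C(F)(F)F`: > 150000 nM

In a functional assay on MCF7 cells (Homo sapiens) for inhibition, read by MTT assay, with a stated time of 24 h (on this read-out higher numbers stand for weaker inhibition and lower numbers for stronger inhibition), compound 1 gives > 150000 nM, which is a limit of the assay and not a number. In this assay compound 2 likewise gives > 150000 nM, again a limit and not a number. Within the data shown here, both values shown therefore sit at the same bound, (the limit of > 150000 nM in this assay, at which 2 of the 2 values shown sit), so no ordering of compound 1 against compound 2 can be read, and no step between measured compounds is available in this set.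

Compound 3 `CCOC(=O)C1=Cc2ccccc2OC1(OCc1cn(CC(=O)Nc2ccccc2F)nn1)C(F)(F)F` is not yet measured in this assay. It differs from compound 1 by (2-fluorophenyl)carbamoyl in place of heptyl on a saturated chain carbon bound to an aromatic nitrogen. With nothing in the measured pair rising above the limit, there is no measured ground for expecting a change in either direction; the step from compound 1 to compound 3 is expected to be none beyond the scatter, with the most likely outcome that this assay again reports only a limit, a step that the limit leaves unreadable from compound 1 to compound 3. Compound 3 is accordingly estimated at 200000 nM, within 60000 nM to 600000 nM, pending the measurement.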

Compound 3, half-maximal inhibitory concentration: 42100 nM
Compound 3: the middle estimate sits 4.8-fold (0.68 log units) above what was measured; measured number outside the range, below it.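

Among the compounds shown, this position on a saturated chain carbon bound to an aromatic nitrogen is the only place where a change brings a value off the limit: in this assay, (2-fluorophenyl)carbamoyl in place of heptyl gives an at least 3.5-fold lower number from compound 1 to compound 3 (0.55 log units; beyond the scatter) with the rest of the structure unchanged. Compounds 1 and 2 alone could not show that anything in this series reads as a number, whereas compound 3 gives 42100 nM, so this position can move the read-out and compound 3 offers a measured reference for further changes here. The true size of the step stays unknown and only its lower bound can be read, because compound 1 holds only a limit: the limit of > 150000 nM in this assay, at which 2 of the 3 values shown sit.

The change replaces the whole substituent in one move, so the compounds shown do not separate the carbamoyl part from the aromatic ring or from its fluorine. On these data alone, whether an unsubstituted phenylcarbamoyl, an amine or a longer chain at this place would give a value on either side of that of compound 3 remains open, as does whether the same substituent would act alike on the free acid form of the core.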